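This account rests on a few compounds, and the source may have more. Where it says the series, first, only, none or still open, it means among the compounds named here.

Working notes on the series. Compound 3 `COc1cccc(-c2nc3c(-c4ccc(Cl)cc4)n[nH]c3c(=O)n2NC(=O)c2ccccc2)c1` is the reference point. In a functional assay on SK-OV-3 cells (Homo sapiens) for cytotoxicity, read by sulforhodamine B assay, with a stated time of 2 days, tested at 100 uM (on this read-out lower numbers stand for less inhibition and higher numbers for more inhibition at the one concentration tested (going by the name of the read-out)), compound 3 gives 81.7%, the highest of the two numbers available; compound 1 `CCCc1n[nH]c2c(=O)n(NC(=O)c3ccccc3)c(-c3cccc(OC)c3)nc12` gives in this assay 9.96%. For the measured compounds named here, the one measured step joining them, a number 71.7 percentage points higher from compound 1 to compound 3 (beyond the scatter), is large and beyond the scatter. Compound 2 `COc1cccc(-c2nc3c(-c4cccc(Cl)c4)n[nH]c3c(=O)n2NC(=O)c2ccccc2)c1` belongs to the same set, but in this assay compound 2 gives "not determined" (no result reported), that is, no result reported, so it adds nothing to the comparison.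

Compound 4 `COc1cccc(-c2nc3c(-c4ccco4)n[nH]c3c(=O)n2NC(=O)c2ccccc2)c1` is not yet measured in this assay. It differs from compound 3 in one place: furan-2-yl in place of 4-chlorophenyl on an aromatic carbon. Going by the values given here, the only step that bears on this position is the one from compound 1 to compound 3, and it shows that the group at this place moves the read-out strongly. Among the compounds with values here, no measured pair tests one aromatic ring against another here, so the direction for compound 4 is uncertain. Compound 4 is expected to keep part of the inhibition of compound 3 because 81.7% came with an aromatic ring at this place, and a step of about a number 26.7 percentage points lower from compound 3 to compound 4 (beyond the scatter) is estimated. Compound 4 is therefore expected to give about 55%, within a range from 20% to 85%.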

Compound 4, a percentage reported as inhibition, at one concentration (the size of the read-out at that concentration, not a potency): 35.2%
For compound 4 the middle estimate is 19.8 percentage points above the measured one; low and high end bracket the measured number.
By their numbers in this assay, from the lowest: compound 1; then compound 4; then compound 3.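

In this assay, furan-2-yl in place of 4-chlorophenyl gives a number 46.5 percentage points lower from compound 3 to compound 4 (beyond the scatter), so the inhibition at this place is not the same for every aromatic ring. Furan-2-yl in place of propyl gives a number 25.2 percentage points higher from compound 1 to compound 4 (beyond the scatter), which places compound 4 between the other two compounds, with a modest gain over propyl and a large loss against 4-chlorophenyl. Nothing measured here accounts for this order.

Still open, going by these compounds, is whether the chlorine or the six-membered ring accounts for the gap between compound 3 and compound 4, a question that a plain phenyl at this place would address. Also open, on these data alone, is how a basic amine or a longer alkyl chain at this place would compare with propyl, and compound 2 gives no result to draw on.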